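Methoxyphenyl Replaces Phenyl on a Weakly Cytotoxic Scaffold

This account rests on a few compounds, and the source may have more. Where it says the series, first, only, none or still open, it means among the compounds named here.

Of the compounds shown here, three with a shared core have been tested in an ADME assay on NIH3T3 cells (Mus musculus) for cytotoxicity, read by MTT assay, with a stated time of 24 h; a higher number here means a weaker inhibitor, a lower number a stronger inhibitor. Compound 1 `O=C(CN1CCN(c2ccccc2Cl)CC1)N1CCN(c2nnc(-c3ccccc3)c(-c3ccccc3)n2)CC1` gives 350000 nM in this assay. Compound 2 `Cc1ccc(-c2nnc(N3CCN(C(=O)CN4CCN(c5ccccc5Cl)CC4)CC3)nc2-c2ccc(C)cc2)cc1` reaches only the limit of the assay, > 859000 nM, and no number. Compound 3 `COc1ccc(-c2nnc(N3CCN(C(=O)CN4CCN(c5ccccc5)CC4)CC3)nc2-c2ccc(OC)cc2)cc1` likewise stands at a limit, > 863000 nM, so for compound 3 only a boundary is known, and of the three values shown two are limits of this kind, the limit of > 859000 nM in this assay, at which 1 of the 3 values shown sits, and (the limit of > 863000 nM in this assay, at which 1 of the 3 values shown sits). Compound 4 `COc1ccc(-c2nnc(N3CCN(C(=O)CN4CCN(c5ccc(OC)cc5)CC4)CC3)nc2-c2ccc(OC)cc2)cc1` differs from compound 3 by a single change: methoxy in place of hydrogen on an aromatic carbon, sitting para to a large group, which read one bond further out is phenyl to 4-methoxyphenyl. Going by the values given here, no measured step of the same kind is available, and compound 3 itself sits at a limit, so no step beyond the usual scatter is expected in this assay; compound 4 is expected to remain at or above the assay boundary. The estimate for compound 4 is 900000 nM, with a range from 400000 nM to 2000000 nM, which as a step means a step that the limit leaves unreadable from compound 3 to compound 4 and is expected to appear as a limit rather than a number.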

Compound 4, half-maximal inhibitory concentration: > 821000 nM
Compound 4 ended at the assay's limit; the forecaster's own chance of this, stated with the estimate: 85%; the middle value is on the limit's open side.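

Compound 3 and compound 4 both stand at limits and not at numbers, so no step can be read between them in this assay. The compounds shown leave open whether the change from phenyl to 4-methoxyphenyl has any effect there.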